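Ethyl to benzyl on the carbamate: the next step

The compounds below may be only part of what the source reports. "The series", "measured", "known", "first", "only" and "open" are said of these compounds alone.

Compound 1 `CCCCCCCC(=O)Nc1nc2ccc(NC(=O)c3c(Cl)cccc3Cl)cc2s1`: 0.18 ug/mL
Compound 2 `COC(=O)Nc1nc2ccc(NC(=O)c3c(Cl)cccc3Cl)cc2s1`: 0.0095 ug/mL
Compound 3 `CCOC(=O)Nc1nc2ccc(NC(=O)c3c(Cl)cccc3Cl)cc2s1`: 0.0026 ug/mL

Three compounds share one core and differ only in the group on the carbonyl carbon at one end. In a functional assay on WI-38 VA13 cells (Homo sapiens) for cytotoxicity (on this read-out lower numbers stand for an effect already at smaller amounts and higher numbers for an effect only at larger amounts of compound), compound 3 gives the lowest number of the three: the step of a 3.7-fold lower number from compound 2 to compound 3 (0.56 log units; beyond the scatter) is modest, while a 69-fold lower number from compound 1 to compound 3 (1.84 log units; beyond the scatter) is large, as is a 19-fold lower number from compound 1 to compound 2 (1.28 log units; beyond the scatter).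

Compound 4 `O=C(Nc1nc2ccc(NC(=O)c3c(Cl)cccc3Cl)cc2s1)OCc1ccccc1` carries one further change: phenyl in place of methyl on a saturated chain carbon bound to an oxygen next to a carbonyl group. The step that bears on it most directly is a 3.7-fold lower number from compound 2 to compound 3 (0.56 log units; beyond the scatter), where a single added carbon at that same position lowered the number. Among the measured compounds shown here, the new group is larger again, and no measured step shows what a ring at this position does, so the direction is uncertain. A modest step in this assay either way seems more likely than a large one. The expected result for compound 4 is 0.006 ug/mL, within the range 0.0015 ug/mL to 0.025 ug/mL, which as a step means a 2.3-fold higher number from compound 3 to compound 4 (0.36 log units; beyond the scatter).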

Compound 4, half-maximal effective concentration: 0.018 ug/mL
Compound 4: middle estimate off by 3.0-fold (0.48 log units), on the low side; low and high end bracket the measured number.
By their numbers in this assay, from the lowest: compound 3; then compounds 2 and 4 (each within the scatter of the next); then compound 1.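

In this assay, phenyl in place of methyl on a saturated chain carbon bound to an oxygen next to a carbonyl group gives a 6.9-fold higher number from compound 3 to compound 4 (0.84 log units; beyond the scatter) and so turns around the direction seen when a single carbon was added at this position. Benzyloxy set against methoxy gives a 1.9-fold higher number from compound 2 to compound 4 (0.28 log units; within the scatter) and the two cannot be told apart, so among these three groups the number does not simply fall as the group grows, and compound 3 stands alone at the low end. Set against heptyl, benzyloxy still gives a 10-fold lower number from compound 1 to compound 4 (1.00 log units; beyond the scatter) and keeps the ring-bearing compound well clear of the heptyl one.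

From the compounds shown here alone, whether a propyl or butyl chain on this oxygen would sit nearer to ethoxy or to benzyloxy stays open. Nothing available explains why the number moves at this position.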